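A few compounds are considered here, and "the series" means these few. Any claim that something is new, unique, unknown or untested is made for them only; others in the source may bear on it.

In an assay on isolated protein for inhibition of Lon protease homolog, mitochondrial (Homo sapiens), read by HTRF, with a stated time of 50 min, in the presence of a further agent that is not named here (on this read-out lower numbers stand for stronger inhibition and higher numbers for weaker inhibition), compound 1 `CC(C)C[C@H](NC(=O)[C@@H](C)NC(=O)c1cnccn1)B(O)O` gives 433 nM, the second highest of the three numbers measured. Compound 2 `CC[C@@H](NC(=O)c1cnccn1)C(=O)N[C@@H](CC(C)C)B(O)O` gives 408 nM, and the step of a 1.1-fold lower number from compound 1 to compound 2 (0.03 log units; within the scatter) lies within the scatter. Compound 3 `CC(C)C[C@H](NC(=O)[C@H](NC(=O)c1cnccn1)C(C)(C)C)B(O)O` gives 2850 nM; the step of a 6.6-fold higher number from compound 1 to compound 3 (0.82 log units; beyond the scatter) is a modest loss, as is a 7.0-fold higher number from compound 2 to compound 3 (0.84 log units; beyond the scatter). Compound 4 `CC(C)C[C@H](NC(=O)[C@@H](CC1CCCCC1)NC(=O)c1cnccn1)B(O)O` differs from compound 1 by cyclohexyl in place of hydrogen on a saturated chain carbon, two bonds along the chain from an amide-type nitrogen and a carbonyl carbon. That is the same saturated chain carbon that carries the added methyl of compound 2, where a change cost nothing beyond the scatter, whereas the loss in compound 3 arose on the carbon bound to the amide-type nitrogen. In this assay the expected step is a 1.4-fold lower number from compound 1 to compound 4 (0.13 log units; within the scatter). Compound 4 is expected to give about 320 nM, within a range from 110 nM to 1100 nM.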

Compound 4, half-maximal inhibitory concentration: 137 nM
Compound 4: the middle estimate sits 2.3-fold (0.37 log units) above what was measured; low and high end bracket the measured number.
By their numbers in this assay, from the lowest: compound 4; then compounds 2 and 1 (each within the scatter of the next); then compound 3.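

In this assay, the saturated chain carbon two bonds along the chain from an amide-type nitrogen and a carbonyl carbon accepts cyclohexyl with a gain beyond the scatter (a 3.2-fold lower number from compound 1 to compound 4 (0.50 log units; beyond the scatter)). Methyl at this place changed nothing beyond the scatter, yet going from methyl to cyclohexyl also gives a gain (a 3.0-fold lower number from compound 2 to compound 4 (0.47 log units; beyond the scatter)). Cyclohexylmethyl in place of tert-butyl on the carbon bound to the amide-type nitrogen gives a large gain (a 21-fold lower number from compound 3 to compound 4 (1.32 log units; beyond the scatter)). On these data alone, whether phenyl, a longer chain or an amine would serve here as well as cyclohexyl remains open. Nothing measured here explains the gain.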